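The compounds below may be only part of what the source reports. "The series", "measured", "known", "first", "only" and "open" are said of these compounds alone.

Compound 1 `Oc1ccc(-c2cc(-c3ccccn3)cc(-c3ccccc3O)n2)cc1` gives 25400 nM in a functional assay on DU-145 cells (Homo sapiens) for cytotoxicity, read by CCK-8 assay (on this read-out lower numbers stand for stronger inhibition and higher numbers for weaker inhibition), and compound 2 `Oc1ccc(-c2cc(-c3ccccn3)cc(-c3cccc(O)c3)n2)cc1` gives 1980 nM in this assay. Within the data shown here, the one measured step, a 13-fold lower number from compound 1 to compound 2 (1.11 log units; beyond the scatter), came from placing 3-hydroxyphenyl instead of 2-hydroxyphenyl on the shared core. Among the measured compounds shown here, compound 2 therefore stands as the lower of the two numbers, with compound 1 the only comparison and far above it.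

Compound 3 `Oc1ccc(-c2cc(-c3ccccn3)cc(-c3ccc(O)cc3)n2)cc1` differs from compound 2 in that (4-hydroxyphenyl in place of 3-hydroxyphenyl on an aromatic carbon). For the measured compounds named here, the only step that bears on this change is the one from compound 1 to compound 2, which concerned the same ring and was large; no measured pair covers the shift from 3-hydroxyphenyl to 4-hydroxyphenyl itself, so that single step cannot be carried over directly. The expected step is a 1.3-fold lower number from compound 2 to compound 3 (0.12 log units; within the scatter), modest and within or near the scatter. Compound 3 is estimated at 1500 nM, with a range from 400 nM to 6000 nM.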

Compound 3, half-maximal inhibitory concentration: > 50000 nM
Compound 3 ended at the assay's limit; the forecaster's own chance of this, stated with the estimate: 3%; middle value at least 33-fold (1.52 log units) from the limit.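

Compound 3 can be read only as a limit, not as a number: the limit of > 50000 nM in this assay, at which 1 of the 3 values shown sits. With the same atoms joined differently, 4-hydroxyphenyl in place of 3-hydroxyphenyl on this aromatic carbon next to the ring nitrogen gives an at least 25-fold higher number from compound 2 to compound 3 (1.40 log units; beyond the scatter), so compound 2, with 3-hydroxyphenyl, now stands as the strongest of the three, with a large step to each of the others, and the earlier single step gave no hint of this. 4-hydroxyphenyl in place of 2-hydroxyphenyl gives an at least 1.9-fold higher number from compound 1 to compound 3 (0.29 log units; that floor lies within the scatter), a floor that does not separate compound 3 from compound 1.

The compounds shown leave open whether the hydroxyl of 3-hydroxyphenyl is itself needed, or whether an amine or a methoxy group in its place, or a plain phenyl, would serve as well. They also leave open how far compound 3 lies beyond its limit.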